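From Isobutyl to Cyclopentyl on the Amide Nitrogen

The compounds below may be only part of what the source reports. "The series", "measured", "known", "first", "only" and "open" are said of these compounds alone.

Of the compounds shown here, two with a shared core have been measured in a functional assay on PC-3 cells (Homo sapiens) for inhibition, read by sulforhodamine B assay, with a stated time of 72 h; a lower number here means a stronger inhibitor, a higher number a weaker inhibitor. There, compound 1 (`Nc1sc(-c2ccc(Cl)cc2)c(-c2ccc(Cl)cc2)c1C(=O)NC1CCC(O)CC1`) gives 5670 nM, while compound 2 (`CC(C)CNC(=O)c1c(N)sc(-c2ccc(Cl)cc2)c1-c1ccc(Cl)cc1`) gives 13200 nM, the higher of the two numbers and so the weaker result of the pair.

Compound 3 (`Nc1sc(-c2ccc(Cl)cc2)c(-c2ccc(Cl)cc2)c1C(=O)NC1CCCC1`) has not yet been measured. It carries cyclopentyl in place of isobutyl on an amide-type nitrogen. Among the measured compounds shown here, only one measured step bears on this change. Putting isobutyl in place of 4-hydroxycyclohexyl at the same nitrogen gave a 2.3-fold higher number from compound 1 to compound 2 (0.37 log units; beyond the scatter), a modest step. For the measured compounds named here, no measured compound carries cyclopentyl, so this single comparison is a thin guide. With that modest step as the only reference, a large change is not expected in this assay. A small move towards a lower number is expected, probably within the scatter: a 1.5-fold lower number from compound 2 to compound 3 (0.17 log units; within the scatter). In this assay the estimated value for compound 3 is 9000 nM, with an expected range from 4000 nM to 20000 nM.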

Compound 3, half-maximal inhibitory concentration: 21200 nM
The estimate for compound 3 lay 2.4-fold (0.37 log units) below the measured number; the measured number lies above the stated range.
By their numbers in this assay, from the lowest: compound 1; then compounds 2 and 3 (each within the scatter of the next).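

In this assay, the swap of isobutyl for cyclopentyl gives a 1.6-fold higher number from compound 2 to compound 3 (0.21 log units; within the scatter) and so, at this amide-type nitrogen, closing the carbon substituent into a five-membered ring does not set compound 3 apart from compound 2. Having a ring on this nitrogen is therefore not enough to match compound 1, as the comparison with 4-hydroxycyclohexyl shows a 3.7-fold higher number from compound 1 to compound 3 (0.57 log units; beyond the scatter) and leaves compound 1 the strongest of the three, with both carbon-only substituents on the weaker side of it. Nothing available gives a measured reason for these differences.

The compounds shown cannot separate the hydroxyl of compound 1 from its six-membered ring, so a plain cyclohexyl on the same nitrogen is the group that would tell which of the two features goes with the lower number. Also open, going by these compounds, is whether a 4-aminocyclohexyl group, a carboxylic acid on the ring or a longer chain in place of isobutyl would stay with compound 1, stay with compounds 2 and 3, or fall elsewhere in this assay.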